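Swapping the oxadiazole group on the side chain of compound 2

This account rests on a few compounds, and the source may have more. Where it says the series, first, only, none or still open, it means among the compounds named here.

Compound 1 `O=c1[nH]nc2ccc(-c3ccc(Oc4ccc(F)cc4)cc3)cn12`: 6.58 h
Compound 2 `Cc1noc(Cn2nc3ccc(-c4ccc(Oc5ccc(F)cc5)cc4)cn3c2=O)n1`: 2.12 h
Compound 3 `O=c1n(Cc2noc(CO)n2)nc2ccc(-c3ccc(Oc4ccc(F)cc4)cc3)cn12`: not yet measured

In an ADME assay on microsomes (Homo sapiens) for metabolic stability (a higher number here means that the compound lasts longer, a lower number that the compound disappears faster), compound 2 has the lower of the two measured values. Compound 3 alters its side chain: 5-(hydroxymethyl)-1,2,4-oxadiazol-3-yl in place of 3-methyl-1,2,4-oxadiazol-5-yl on a saturated chain carbon bound to an aromatic nitrogen. Here 5-(hydroxymethyl)-1,2,4-oxadiazol-3-yl stands in place of 3-methyl-1,2,4-oxadiazol-5-yl on a saturated chain carbon bound to an aromatic nitrogen. For the measured compounds named here, only one measured step bears on this: a 3.1-fold lower number from compound 1 to compound 2 (0.49 log units; beyond the scatter), which came with adding the whole side chain. That step does not test a swap of one oxadiazole group for another, and compound 3 keeps a side chain there. A smaller move is therefore expected, with only a weak lean upward. The expected result is a 1.3-fold higher number from compound 2 to compound 3 (0.11 log units; within the scatter). For compound 3 the estimated half-life is 2.7 h, with a range of 1.2 h to 6 h.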

Compound 3, half-life in the Homo sapiens assay: 1.35 h
The estimate for compound 3 lay 2.0-fold (0.30 log units) above the measured number, and the stated range covers the measured number.
By their numbers in the Homo sapiens assay, from the lowest: compounds 3 and 2 (each within the scatter of the next); then compound 1.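

In the Homo sapiens assay compound 2 gives 2.12 h and compound 3 gives 1.35 h; the swap between the two oxadiazole groups gives a 1.6-fold lower number from compound 2 to compound 3 (0.20 log units; within the scatter), so moving to 5-(hydroxymethyl)-1,2,4-oxadiazol-3-yl on this saturated chain carbon brings no change that stands clear of repeat scatter. Set against hydrogen on the aromatic nitrogen, the new side chain gives a 4.9-fold lower number from compound 1 to compound 3 (0.69 log units; beyond the scatter), which points the same way as the first side chain did, so a second oxadiazole side chain also comes with a shorter half-life. In a physicochemical assay for lipophilicity (on this read-out higher numbers stand for higher lipophilicity and lower numbers for lower lipophilicity), compound 2 gives 3 and compound 3 gives 2.8; the same swap gives a number 0.20 log units lower from compound 2 to compound 3 (within the scatter), and nothing available explains any of these steps.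

As far as these compounds go, it remains open whether the lower numbers go with the oxadiazole ring or with the saturated chain carbon that carries it. Also open, from the compounds shown here alone, is how an amine, a carboxylic acid or a longer chain would behave on this aromatic nitrogen.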